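Removing a Single Fluorine from the Anilino Ring

The source may hold more compounds than are shown below. What is called first, only, known or untested is meant among the compounds shown, and "the series" means these compounds.

Three measured compounds share one core and differ only in the ring attached to the anilino nitrogen. Compound 1 `CC(C)c1ccc(-c2nc(SCc3cn(CC(=O)NC(=O)Nc4ccccn4)nn3)nc(Nc3cccc(C(F)(F)F)c3)c2C#N)cc1` carries a trifluoromethyl group on that ring, and in a functional assay on ECa-109 cells (Homo sapiens) for inhibition, read by MTT assay, with a stated time of 72 h (a higher number here means a weaker inhibitor, a lower number a stronger inhibitor), compound 1 gives 24200 nM. Compound 2 `CC(C)c1ccc(-c2nc(SCc3cn(CC(=O)NC(=O)Nc4ccccn4)nn3)nc(Nc3cccc([N+](=O)[O-])c3)c2C#N)cc1` carries a nitro group instead, and in this assay compound 2 gives 31300 nM; a 1.3-fold higher number from compound 1 to compound 2 (0.11 log units; within the scatter). Compound 3 `CC(C)c1ccc(-c2nc(SCc3cn(CC(=O)NC(=O)Nc4ccccn4)nn3)nc(Nc3ccccc3F)c2C#N)cc1` carries a single fluoro group, and in this assay compound 3 gives 15500 nM, the lowest of the three numbers: a 1.6-fold lower number from compound 1 to compound 3 (0.19 log units; within the scatter), while a 2.0-fold lower number from compound 2 to compound 3 (0.31 log units; beyond the scatter).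

Compound 4 `CC(C)c1ccc(-c2nc(SCc3cn(CC(=O)NC(=O)Nc4ccccn4)nn3)nc(Nc3ccccc3)c2C#N)cc1` has not yet been measured. It differs from compound 3 in one place: hydrogen in place of fluoro on an aromatic carbon. For the measured compounds named here, no measured step removes a group in this way. The two steps that touch this ring swap one substituted ring for another, and they move the number only modestly, one within the scatter and one just beyond it. Since every change on this ring so far has had little effect, a small step, or none beyond the scatter, is expected in this assay: a 1.3-fold higher number from compound 3 to compound 4 (0.11 log units; within the scatter). Compound 4 is therefore estimated at 20000 nM, with a likely range from 8000 nM to 50000 nM.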

Compound 4, half-maximal inhibitory concentration: > 64000 nM
Compound 4: no number, only a limit; the forecaster's own chance of this, stated with the estimate: 0%; middle value at least 3.2-fold (0.50 log units) from the limit.
By their numbers in this assay, from the lowest: compounds 3, 1 and 2 (each within the scatter of the next, the first and the last beyond it). At a limit, above all of these: compound 4.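

Compound 4, with its plain phenyl ring, gives no number in this assay, only a limit of the assay: the limit of > 64000 nM in this assay, at which 1 of the 4 values shown sits. All three steps to this unsubstituted ring lie beyond the scatter: an at least 4.1-fold higher number from compound 3 to compound 4 (0.61 log units; beyond the scatter), an at least 2.0-fold higher number from compound 2 to compound 4 (0.31 log units; beyond the scatter) and an at least 2.6-fold higher number from compound 1 to compound 4 (0.42 log units; beyond the scatter). The earlier compounds only swapped one substituted ring for another, so they could not show that this ring tolerates such swaps far better than it tolerates the loss of its substituent; among the four compounds shown, none goes against this, as fluoro, nitro and trifluoromethyl all give measurable numbers while hydrogen does not.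

On these data alone, how far the true value of compound 4 lies past its limit stays open, so the full size of these steps is unknown. As far as these compounds go, it also stays open whether a different substituent on this ring, such as an amine, a methoxy group or a chlorine, would give a number in the range of compound 1, compound 2 and compound 3, or whether only some groups can replace hydrogen here.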